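Notes on the step from compound 3 to compound 4

The compounds below may be only part of what the source reports. "The series", "measured", "known", "first", "only" and "open" are said of these compounds alone.

The series keeps a shared core and varies the aryl group on an amine nitrogen in a ring. In a functional assay on MCF7 cells (Homo sapiens) for antiproliferative activity, read by MTT assay, with a stated time of 48 h (on this read-out lower numbers stand for stronger inhibition and higher numbers for weaker inhibition), compound 1 `O=C(/C=C/c1ccc(O)c(O)c1)N1CCN(c2ccccc2F)CC1` gives 1.38 ug/mL. Compound 2 `O=C(/C=C/c1ccc(O)c(O)c1)N1CCN(c2ccc(F)cc2)CC1` gives 1.44 ug/mL. Compound 3 `COc1ccc(N2CCN(C(=O)/C=C/c3ccc(O)c(O)c3)CC2)cc1` gives 0.52 ug/mL, the lowest of the three numbers.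

Compound 4 `O=C(/C=C/c1ccc(O)c(O)c1)N1CCN(c2ccc([N+](=O)[O-])cc2)CC1` carries nitro in place of methoxy on an aromatic carbon, para to a large group: nitro in place of methoxy on an aromatic carbon.

The closest measured evidence is the change of methoxy in place of fluoro on an aromatic carbon, which gave a 2.8-fold lower number from compound 2 to compound 3 (0.44 log units; beyond the scatter). The comparison with the 2-fluorophenyl analogue gave a 2.7-fold lower number from compound 1 to compound 3 (0.42 log units; beyond the scatter). Exchanging 2-fluorophenyl for 4-fluorophenyl gave a 1.0-fold higher number from compound 1 to compound 2 (0.02 log units; within the scatter), which lies within the scatter. Going by the values given here, no measured compound carries nitro, so these steps bear on the change only indirectly. Among the compounds with values here, compound 3 is the only compound with methoxy, and both other groups tested sit at higher numbers. A modest step towards a higher number in this assay is therefore expected, although a result within the scatter remains possible. The expected change is a 2.3-fold higher number from compound 3 to compound 4 (0.36 log units; beyond the scatter). Compound 4 is estimated at 1.2 ug/mL, with an expected range from 0.4 ug/mL to 3.5 ug/mL.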

Compound 4, half-maximal inhibitory concentration: 1.14 ug/mL
For compound 4 the middle estimate is 1.1-fold (0.02 log units) above the measured one; measured number inside the range.
By their numbers in this assay, from the lowest: compound 3; then compounds 4, 1 and 2 (each within the scatter of the next).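

In this assay, the change from 4-methoxyphenyl to 4-nitrophenyl gives a 2.2-fold higher number from compound 3 to compound 4 (0.34 log units; beyond the scatter), so compound 3 now has steps beyond the scatter to all three other compounds and remains the strongest of the four. Nitro and fluoro at this place cannot be told apart, since a 1.3-fold lower number from compound 2 to compound 4 (0.10 log units; within the scatter) and a 1.2-fold lower number from compound 1 to compound 4 (0.08 log units; within the scatter) both lie within the scatter; among the groups shown, only methoxy stands apart from the rest. Nothing at hand explains why methoxy differs from nitro and fluoro here.

Going by these compounds, it remains open whether the lower number belongs to methoxy alone or is shared by other groups on this aromatic carbon, such as a hydroxyl, an amine or a longer alkoxy chain. On these data alone, all four compounds also keep the shared core, so it is unknown whether the step from methoxy to nitro would keep its size if the core were changed.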